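Methylsulfanyl for ethyl: compound 4 against compound 2

The source may hold more compounds than are shown below. What is called first, only, known or untested is meant among the compounds shown, and "the series" means these compounds.

Measured so far in a functional assay on the whole organism (strain Sprague-Dawley) for inhibition, with Rattus norvegicus as the target; a lower number here means that less compound is needed, a higher number that more compound is needed for the effect:
- compound 1, `c1cc2ncc(-c3nn[nH]n3)cc2cc1OC1CCCCC1`, gives 5 mg/kg
- compound 2, `CCc1cccc2c(=O)c(-c3nn[nH]n3)c[nH]c12`, gives 0.312 mg/kg
- compound 3, `CCCCc1ccc2ncc(-c3nn[nH]n3)cc2c1`, gives 5 mg/kg

Compound 2 stands lowest of the three numbers in this assay; compounds 1 and 3 both sit well apart from it, beyond the scatter, and their two values are the same as each other. For the measured compounds named here, the single measured step, no change at the digits printed from compound 1 to compound 3 (within the scatter), replaces one side group with another on an aromatic carbon of the core of compound 1 and stays within the scatter. It does not touch the core shared by compound 2 and compound 4.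

Compound 4, `CSc1cccc2c(=O)c(-c3nn[nH]n3)c[nH]c12`, differs from compound 2 in one place: methylsulfanyl in place of ethyl on an aromatic carbon. Going by the values given here, no measured pair carries a methylsulfanyl, and no measured pair changes a group on the core of compound 2, so the only bearing comes from the step from compound 1 to compound 3, which was a swap of one side group for another on an aromatic carbon and showed no change. On that basis no step beyond the scatter is expected in this assay; the step of a 1.3-fold higher number from compound 2 to compound 4 (0.11 log units; within the scatter) is the expected outcome. Compound 4 is therefore estimated at 0.4 mg/kg, with a range from 0.15 mg/kg to 1.25 mg/kg.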

Compound 4, minimum effective dose: 10 mg/kg
Compound 4: the middle estimate sits 25-fold (1.40 log units) below what was measured; the whole stated range lies below it.
By their numbers in this assay, from the lowest: compound 2; then compounds 1, 3 and 4 (each within the scatter of the next).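

On the core of compound 2, this aromatic carbon does not tolerate every small group alike: in this assay methylsulfanyl in place of ethyl gives a 32-fold higher number from compound 2 to compound 4 (1.51 log units; beyond the scatter) even though both groups count 2 heavy atoms. The side-group swap with no change at the digits printed from compound 1 to compound 3 (within the scatter) on the other core therefore gives no guide to this position. The counted differences are a sulfur in place of a carbon and one added hydrogen-bond acceptor, and nothing available connects either difference with the size of this step.

Open is whether ethyl is itself favourable here or methylsulfanyl is specifically unfavourable, since the compounds shown give no reading for methoxy, propyl or an amine on this carbon. Also open, on these data alone, is whether butyl or cyclohexyloxy would behave the same way on the core of compound 2.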